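Side-chain replacement at the four-membered ring carbon

The source may report more compounds than this note shows. Statements on the series, on what has been measured and on what is new or still open speak of the compounds shown alone.

Compound 1 `COC(=O)[C@H](O)[C@H]1C(=O)N2C(C(=O)O)=C(C(C)(C)C)O[C@H]12` carries hydroxy(methoxycarbonyl)methyl on a saturated ring carbon of its core. Going by the values given here, in an ADME assay, in phosphate buffer, at 28 degrees C, at pH 7.0 (on this read-out higher numbers stand for a longer-lived compound and lower numbers for a shorter-lived compound), compound 1 gives 6.7 h, the second highest of the three numbers so far. Compound 2 `Cn1cc([C@H](O)[C@H]2C(=O)N3C(C(=O)O)=C(C(C)(C)C)O[C@H]23)nn1` gives 7 h and compound 3 `CC(C)(C)C1=C(C(=O)O)N2C(=O)[C@H]([C@@H](O)c3ccncc3)[C@H]2O1` gives 6 h; the steps of a 1.0-fold higher number from compound 1 to compound 2 (0.02 log units; within the scatter), a 1.1-fold lower number from compound 1 to compound 3 (0.05 log units; within the scatter) and a 1.2-fold lower number from compound 2 to compound 3 (0.07 log units; within the scatter) are all within the scatter, so the three measured compounds cannot be ordered on this read-out.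

Compound 4 `CC(=O)NC[C@H]1C(=O)N2C(C(=O)O)=C(C(C)(C)C)O[C@H]12` is not yet measured. It differs from compound 1 by acetamidomethyl in place of hydroxy(methoxycarbonyl)methyl on a saturated ring carbon. Among the compounds with values here, no measured step exchanges the whole side chain at this position. The nearest evidence is that the three exchanges on the saturated chain carbon, a 1.0-fold higher number from compound 1 to compound 2 (0.02 log units; within the scatter) and a 1.1-fold lower number from compound 1 to compound 3 (0.05 log units; within the scatter), left this assay unchanged within the scatter. On that basis no step beyond the scatter is expected for a 1.0-fold lower number from compound 1 to compound 4 (0.01 log units; within the scatter), and compound 4 is estimated at 6.5 h, with a range from 3.3 h to 13 h.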

Compound 4, half-life: < 3 h
Compound 4: no number, only a limit; the forecaster's own chance of this, stated with the estimate: 5%; middle value at least 2.1-fold (0.33 log units) from the limit.
By their numbers in this assay, from the lowest: compounds 3, 1 and 2 (each within the scatter of the next). At a limit, below all of these: compound 4.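

In this assay compound 4 gives only a limit, < 3 h, not a number. Acetamidomethyl in place of hydroxy(methoxycarbonyl)methyl on the saturated ring carbon still gives an at least 2.2-fold lower number from compound 1 to compound 4 (0.34 log units; beyond the scatter), the only step beyond the scatter among the compounds shown. This position is therefore not indifferent to the side chain it carries, even though the exchanges on the saturated chain carbon among compound 1, compound 2 and compound 3 all stayed within the scatter, and the size of the new step is bounded on one side only: the limit of < 3 h in this assay, at which 1 of the 4 values shown sits.

Compound 1, compound 2 and compound 3 all keep the hydroxyl on the chain carbon, while compound 4 lacks it and also has an amide in the chain, so the compounds shown do not separate these two changes. As far as these compounds go, whether a simple hydroxymethyl, an aminomethyl or a longer acylamino chain at this ring carbon would sit with compound 1 or with compound 4 remains open.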